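A Halogen Swap on the Fluorinated Ring of Compound 3

A few compounds are considered here, and "the series" means these few. Any claim that something is new, unique, unknown or untested is made for them only; others in the source may bear on it.

Three close relatives have been tested in an ADME assay on NIH3T3 cells (Mus musculus) for cytotoxicity, read by XTT assay, with a stated time of 24 h; a lower number here means a stronger inhibitor, a higher number a weaker inhibitor. Compound 1 `Fc1cccc(/C=N/NC(=S)Nc2cccc3ccccc23)c1F` gave a reading of > 500 ug/mL, which is a limit of the assay rather than a measured number. Compound 2 `Fc1cc(F)cc(/C=N/NC(=S)Nc2cccc3ccccc23)c1` likewise gave > 500 ug/mL, again only a limit. Compound 3 `Fc1ccc(/C=N/NC(=S)Nc2cccc3ccccc23)cc1F` stands at > 500 ug/mL, also a limit. The three measured compounds therefore show no readable difference: the steps a step that the two limits leave unreadable from compound 1 to compound 2, a step that the two limits leave unreadable from compound 1 to compound 3 and a step that the two limits leave unreadable from compound 2 to compound 3 each run between two limits, so their size cannot be read. What the numbers show is the limit of > 500 ug/mL in this assay, at which 3 of the 3 values shown sit.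

Compound 4 `Fc1cccc(Cl)c1/C=N/NC(=S)Nc1cccc2ccccc12` has not yet been measured. It differs from compound 3 by 2-chloro-6-fluorophenyl in place of 3,4-difluorophenyl on a carbon with a double bond to nitrogen. Among the measured compounds shown here, none of the measured steps exchanges a fluorine for a chlorine on this ring, so none bears directly on the change; what they do show is that each rearrangement of the two fluorines tried so far left the reading at the limit. Compound 4 is therefore expected to behave the same way, with an expected step of a number no higher from compound 3 to compound 4 (the limit leaves the size open) that should not pass beyond the scatter. For compound 4 the expected value in this assay is 500 ug/mL, with a range from 250 ug/mL to 1000 ug/mL, most likely reported once more as a limit.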

Compound 4, half-maximal inhibitory concentration: > 500 ug/mL
Compound 4: a limit, no number (the forecaster's own chance of this, stated with the estimate: 85%); the middle value lies on the limit itself.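

In this assay compound 4 gives > 500 ug/mL as a limit and not a number. Its steps to compound 1, compound 2 and compound 3 all join two limits, so none of them can be read: the limit of > 500 ug/mL in this assay, at which 4 of the 4 values shown sit. Left open is the actual number for each of the four compounds, and so whether changing the groups on this ring alters the reading at all.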